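Amino in place of hydrogen on compound 1

This account rests on a few compounds, and the source may have more. Where it says the series, first, only, none or still open, it means among the compounds named here.

Values in a functional assay on MCF7 cells (Homo sapiens) for inhibition, with a stated time of 48 h; a higher number here means a weaker inhibitor, a lower number a stronger inhibitor:
- compound 1 `COc1cc(Sc2c[nH]c3ccccc23)cc(OC)c1OC`: 34 nM
- compound 2 `COc1cc(Sc2c(C)[nH]c3ccccc23)cc(OC)c1OC`: 46 nM

Compound 1 and compound 2 stand within the scatter of each other, so neither leads. Next is compound 3 `COc1cc(Sc2c[nH]c3ccc(N)cc23)cc(OC)c1OC`, with amino in place of hydrogen on an aromatic carbon. Within the data shown here, the only measured step, a 1.4-fold higher number from compound 1 to compound 2 (0.13 log units; within the scatter), is methyl in place of hydrogen on an aromatic carbon. Among the measured compounds shown here, that is a different group on a different carbon, so it bears only loosely, and no amino step has been measured. A small rise in this assay is expected, with little confidence in its direction. The estimated step is a 1.8-fold higher number from compound 1 to compound 3 (0.25 log units; within the scatter). Compound 3 is expected at 60 nM, with an estimated range of 15 nM to 240 nM.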

Compound 3, half-maximal inhibitory concentration: 260 nM
Compound 3: the middle estimate sits 4.3-fold (0.64 log units) below what was measured, and the stated range ends below it.
By their numbers in this assay, from the lowest: compounds 1 and 2 (each within the scatter of the next); then compound 3.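

In this assay, among these compounds, amino in place of hydrogen on an aromatic carbon of the six-membered aromatic ring of carbon only gives a 7.6-fold higher number from compound 1 to compound 3 (0.88 log units; beyond the scatter) and is the first step beyond the scatter, whereas a 1.4-fold higher number from compound 1 to compound 2 (0.13 log units; within the scatter) stays within it. This shows that the core of compound 1 does not accept every small change without a loss of inhibition, although the reading at this carbon rests on a single pair. Nothing at hand accounts for the size of this step.

On these data alone, whether a hydroxyl, a nitro group or an acetamide on the same carbon would follow amino remains open. So does whether amino on another carbon of that ring would give a step of similar size.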